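The compounds below may be only part of what the source reports. "The series", "measured", "known", "first", "only" and "open" are said of these compounds alone.

Compound 1, `COc1ccc(C(=O)/C=C/c2ccc(-n3ccnc3)cc2)c2c1C=CC(C)(C)O2`, gives > 6600 nM in a functional assay on HT-29 cells (Homo sapiens) for antiproliferative activity, read by MTT assay, with a stated time of 24 h (on this read-out higher numbers stand for weaker inhibition and lower numbers for stronger inhibition), a limit of the assay rather than a number.
Compound 2, `COc1ccc(C(=O)/C=C/c2ccccc2)c2c1C=CC(C)(C)O2`, gives > 10000 nM in this assay, also a limit rather than a number.
Compound 3, `COc1ccc(C(=O)/C=C/c2cccc(C(F)(F)F)c2)c2c1C=CC(C)(C)O2`, gives 9050 nM in this assay.

Compound 2 therefore stands at a limit, and one further value shown is a limit as well. Compound 4, `COc1ccc(C(=O)/C=C/c2cc(Cl)ccc2O)c2c1C=CC(C)(C)O2`, differs from compound 2 by 5-chloro-2-hydroxyphenyl in place of phenyl on a double-bonded chain carbon bound to a double-bonded chain carbon. The measured steps on this ring are a step that the two limits leave unreadable from compound 1 to compound 2, unreadable at the limit of > 10000 nM in this assay, at which 1 of the 3 values shown sits, and (the limit of > 6600 nM in this assay, at which 1 of the 3 values shown sits), and an at least 1.1-fold lower number from compound 2 to compound 3 (0.04 log units; that floor lies within the scatter), within the scatter. Neither gives ground to expect a step beyond the scatter in this assay. Compound 4 is estimated at 8000 nM, from 3000 nM to 20000 nM. This amounts to an expected step of an at least 1.2-fold lower number from compound 2 to compound 4 (0.09 log units; that floor lies within the scatter).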

Compound 4, half-maximal inhibitory concentration: 4970 nM
The estimate for compound 4 lay 1.6-fold (0.21 log units) above the measured number; low and high end bracket the measured number.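

With 5-chloro-2-hydroxyphenyl in place of phenyl on this chain carbon, the change gives an at least 2.0-fold lower number from compound 2 to compound 4 (0.30 log units; that floor lies within the scatter) in this assay. Among these compounds, this is the first change at this position to reach a floor of that size, although the floor itself does not go beyond the scatter. Compound 2 stands at a limit, so only a floor can be given for the step: the limit of > 10000 nM in this assay, at which 1 of the 4 values shown sits.

The compounds shown do not separate the chloro part of the new group from its hydroxy part. They also leave open how an amine or a carboxylic acid on this ring would read in this assay.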